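Replacing the 2,5-dihydroxyphenyl Group of Compound 3

This account rests on a few compounds, and the source may have more. Where it says the series, first, only, none or still open, it means among the compounds named here.

In a functional assay on HepG2 cells (Homo sapiens) for inhibition, read by MTT assay, with a stated time of 48 h (on this read-out lower numbers stand for stronger inhibition and higher numbers for weaker inhibition), compound 1 `COc1cc(OC)c(OC)cc1/C=C/C(=O)c1cc(OC)c(OC)c(OC)c1` gives 16100 nM and compound 2 `COc1cc(C(=O)/C=C/c2ccc(O)cc2)cc(OC)c1OC` gives 16000 nM as values within the scatter of each other. Compound 3 `COc1cc(C(=O)/C=C/c2cc(O)ccc2O)cc(OC)c1OC` stands at > 100000 nM as a limit and not as a number. Going by the values given here, one measured step bears on this place: an at least 6.2-fold higher number from compound 2 to compound 3 (0.79 log units; beyond the scatter) with 2,5-dihydroxyphenyl in place of 4-hydroxyphenyl. The move to compound 4 `COc1cc(C(=O)/C=C/c2ccc(F)cc2)cc(OC)c1OC` is 4-fluorophenyl in place of 2,5-dihydroxyphenyl on a double-bonded chain carbon bound to a double-bonded chain carbon on a double-bonded chain carbon bound to a double-bonded chain carbon. The expectation leans on compound 2 at 16000 nM whose 4-hydroxyphenyl is the measured group closest to 4-fluorophenyl. An expected step of an at least 5.0-fold lower number from compound 3 to compound 4 (0.69 log units; beyond the scatter) follows, toward a lower number and beyond the scatter. In this assay the expected value for compound 4 is an estimated 20000 nM (range 6000 nM to 60000 nM).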

Compound 4, half-maximal inhibitory concentration: 22000 nM
Beside the measured number, compound 4's estimate is 1.1-fold (0.04 log units) below it; the measured number falls inside the stated range.
By their numbers in this assay, from the lowest: compounds 2, 1 and 4 (each within the scatter of the next). At a limit, above all of these: compound 3.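

In this assay the exchange of 2,5-dihydroxyphenyl for 4-fluorophenyl reads as an at least 4.5-fold lower number from compound 3 to compound 4 (0.65 log units; beyond the scatter), so the loss seen with 2,5-dihydroxyphenyl does not carry over to every replacement at this place. Compound 3 remains a limit and not a number: the limit of > 100000 nM in this assay, at which 1 of the 4 values shown sits. The second comparison reads as a 1.4-fold higher number from compound 2 to compound 4 (0.14 log units; within the scatter), so with fluoro in place of hydroxy on an aromatic carbon, a hydroxy group is not needed to keep this level of inhibition. As far as these compounds go, whether an amine or a chloro group on that aromatic carbon would move the number beyond the scatter stays open.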